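The source may hold more compounds than are shown below. What is called first, only, known or untested is meant among the compounds shown, and "the series" means these compounds.

Measured so far in an assay on CHO cells with Alpha-2B adrenergic receptor (Homo sapiens) as the target; a lower number here means a smaller maximal response, a higher number a larger maximal response:
compound 1, `C=CCc1cccc(CC=C)c1OC(C)C1=NCCN1`, 0.65
compound 2, `CC(Oc1ccccc1Br)C1=NCCN1`, 0.4
compound 3, `COc1ccccc1OC(C)C1=NCCN1`, 0.5

Compound 2 gives the lowest of these three numbers; compound 3 is nearest, the step a number 0.10 higher from compound 2 to compound 3 (within the scatter) lying within the scatter, while compound 1 stands further off, beyond it. Compound 4, `CC(Oc1ccccc1C=O)C1=NCCN1`, has not yet been measured in this assay. Relative to compound 2 the change is formyl in place of bromo on an aromatic carbon. Among the compounds with values here, the one measured step that bears on this change is a number 0.10 higher from compound 2 to compound 3 (within the scatter), in which another group replaced the same bromo on an aromatic carbon, and it stayed within the scatter. For compound 4 the step a number 0.050 higher from compound 2 to compound 4 (within the scatter) is therefore expected, nothing beyond the scatter. Compound 4 is expected to give 0.45 in this assay, in the range 0.3 to 0.65.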

Compound 4, intrinsic activity: the largest response reached, as a fraction of the reference agonist's: 0.5
Compound 4: middle estimate off by 0.050, on the low side; measured number inside the range.
By their numbers in this assay, from the lowest: compounds 2, 3 and 4 (each within the scatter of the next); then compound 1.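

In this assay, formyl is a second replacement for bromo on this aromatic carbon (a number 0.10 higher from compound 2 to compound 4 (within the scatter)), and against methoxy it gives (no change at the digits printed from compound 3 to compound 4 (within the scatter)). Bromo, methoxy and formyl therefore all lie within the scatter of one another at this place, so a group with a carbonyl does not separate from the other two. Nothing available explains this closeness. Still open, on these data alone, is whether an amine or a carboxylic acid on this aromatic carbon would give a step beyond the scatter. Also open, as far as these compounds go, is whether formyl would read the same elsewhere on the six-membered aromatic ring.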